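The source may hold more compounds than are shown below. What is called first, only, known or untested is meant among the compounds shown, and "the series" means these compounds.

Measured so far in an in vitro assay on UC11MG cells for binding affinity to Substance-P receptor (Homo sapiens), read by radioligand binding; a higher number here means a weaker inhibitor, a lower number a stronger inhibitor:
Compound 1 `Cc1nc2ccccc2c(-c2ccccc2)c1C(=O)N(C)Cc1cc(C(F)(F)F)cc(C(F)(F)F)c1` gives 3.1 nM.
Compound 2 `CN(Cc1cc(C(F)(F)F)cc(C(F)(F)F)c1)C(=O)c1c(CBr)nc2ccccc2c1-c1ccccc1` gives 52 nM.

Compound 2 stands at the higher, weaker end of these two numbers; the step of a 17-fold higher number from compound 1 to compound 2 (1.22 log units; beyond the scatter) is large and well beyond the scatter, and it came from a single change, bromo in place of hydrogen on a saturated chain carbon bound to an aromatic carbon. Compound 3 `COCc1nc2ccccc2c(-c2ccccc2)c1C(=O)N(C)Cc1cc(C(F)(F)F)cc(C(F)(F)F)c1` has not yet been measured. It differs from compound 2 in one place: methoxy in place of bromo on a saturated chain carbon bound to an aromatic carbon. Within the data shown here, only one measured step touches this carbon, and it shows that attaching bromo there costs a great deal of binding. Compound 3 also carries a group on that carbon, but a different one, so the measured step sets the scale rather than the direction with certainty. The expectation is that compound 3 sits between the two measured numbers, with a step of a 3.5-fold lower number from compound 2 to compound 3 (0.54 log units; beyond the scatter) back towards stronger binding. Compound 3 is therefore estimated at 15 nM, within a range from 4 nM to 60 nM.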

Compound 3, half-maximal inhibitory concentration: 11 nM
Compound 3: middle estimate off by 1.4-fold (0.13 log units), on the high side, within the range that was stated.
By their numbers in this assay, from the lowest: compound 1; then compound 3; then compound 2.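

Until now this saturated chain carbon bound to an aromatic carbon had been seen with only hydrogen and bromo, so the large loss of binding could have applied to any group placed there. In this assay, going from bromomethyl to methoxymethyl gives a 4.7-fold lower number from compound 2 to compound 3 (0.67 log units; beyond the scatter) and shows that the cost depends on which group is attached, not merely on something replacing hydrogen. Methoxy still does not fully match hydrogen, with a 3.5-fold higher number from compound 1 to compound 3 (0.55 log units; beyond the scatter) beyond the scatter, so this carbon accepts methoxy at a modest cost, and no measurement shown bears on why methoxy and bromo differ here.

The compounds shown leave open what sets the size of this cost, as hydrogen, bromo and methoxy alone are too few to reveal a trend. On these data alone, it also remains open whether a hydroxyl, an amine or a longer chain such as ethoxy on this same carbon would lose more binding, lose less, or match hydrogen.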